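Swapping the Hydroxyphenyl Ring in a Hydrazone Series

The source may report more compounds than this note shows. Statements on the series, on what has been measured and on what is new or still open speak of the compounds shown alone.

Two measured hydrazones share one core. Compound 1 `O=C(N/N=C/c1cccnc1)c1ccc(-c2nc3ccccc3s2)cc1` carries a pyridine ring; in an assay on isolated protein for inhibition of Maltase-glucoamylase (Homo sapiens), with a stated time of 15 min (a lower number here means a stronger inhibitor, a higher number a weaker inhibitor), compound 1 gives "not active" (no number reported). Within the data shown here, compound 2 `O=C(N/N=C/c1ccccc1O)c1ccc(-c2nc3ccccc3s2)cc1` carries a 2-hydroxyphenyl group; in this assay compound 2 gives 5550 nM, the only number reported, as compound 1 is reported without one. Compound 3 `COc1ccc(/C=N/NC(=O)c2ccc(-c3nc4ccccc4s3)cc2)cc1O` differs by 3-hydroxy-4-methoxyphenyl in place of 2-hydroxyphenyl on a carbon with a double bond to nitrogen. Among the measured compounds shown here, no step between measured compounds exists to guide this change, so only a modest shift is expected, a 1.2-fold lower number from compound 2 to compound 3 (0.09 log units; within the scatter), lying within the usual scatter. Compound 3 is therefore estimated at 4500 nM, with a likely range from 1500 nM to 13000 nM.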

Compound 3, half-maximal inhibitory concentration: "not active" (no number reported)
Compound 3 has no reported number here; there is nothing to compare the estimate with.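

In this assay compound 3 gives "not active" (no number reported), so no step from compound 2 to compound 3 can be read, and no evidence shown bears on this result. The compounds shown leave open which parts of the 2-hydroxyphenyl group of compound 2 matter for its inhibition.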